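Adding an Ethyl Branch to a Methoxyethyl Side Chain

This account rests on a few compounds, and the source may have more. Where it says the series, first, only, none or still open, it means among the compounds named here.

Of the compounds shown here, three sharing one core have been measured in a functional assay on HeLa cells (Homo sapiens) for cytotoxicity, read by MTT assay; on this read-out higher numbers stand for weaker inhibition and lower numbers for stronger inhibition. Compound 1 `CC(C)=CC[C@@H](OC[C@H](C)O)C1=CC(=O)c2c(O)ccc(O)c2C1=O` gives 40300 nM. Compound 2 `COCCO[C@H](CC=C(C)C)C1=CC(=O)c2c(O)ccc(O)c2C1=O` gives 62400 nM, and compound 3 `CCCCC(CC(=O)O[C@H](CC=C(C)C)C1=CC(=O)c2c(O)ccc(O)c2C1=O)OC(C)=O` gives 73500 nM. Compound 2 stands second highest of these three numbers, with compound 3 nearest and compound 1 furthest, both gaps within the scatter. Among the measured compounds shown here, the only measured step, a 1.5-fold higher number from compound 1 to compound 2 (0.19 log units; within the scatter), is also within the scatter. Compound 4 `CCC(CO[C@H](CC=C(C)C)C1=CC(=O)c2c(O)ccc(O)c2C1=O)OC` differs from compound 2 by ethyl in place of hydrogen on a saturated chain carbon bound to an oxygen on a saturated carbon and a saturated chain carbon. For the measured compounds named here, no measured step touches this position, so there is no basis to expect a change beyond the scatter in this assay. The step of a 1.0-fold lower number from compound 2 to compound 4 (0.02 log units; within the scatter) is therefore expected to be small. Compound 4 is expected to give about 60000 nM, between 25000 nM and 150000 nM.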

Compound 4, half-maximal inhibitory concentration: 63500 nM
For compound 4 the middle estimate is 1.1-fold (0.02 log units) below the measured one; the measured number falls inside the stated range.
By their numbers in this assay, from the lowest: compounds 1, 2, 4 and 3 (each within the scatter of the next).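

In this assay, among the compounds shown here, ethyl in place of hydrogen on this saturated chain carbon gives a 1.0-fold higher number from compound 2 to compound 4 (0.01 log units; within the scatter) and is the first measured change at this position, with no step beyond the scatter. The wider swap of 1-hydroxyethyl for 1-methoxypropyl gives a 1.6-fold higher number from compound 1 to compound 4 (0.20 log units; within the scatter) and also stays within the scatter. Nothing available explains either result. From the compounds shown here alone, whether an amine, a carboxylic acid or a longer chain on this same carbon would shift the number beyond the scatter remains open.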